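The compounds below may be only part of what the source reports. "The series", "measured", "known", "first", "only" and "open" are said of these compounds alone.

- Compound 1 `O=C(CCCCCNc1c(NCc2ccccc2)c(=O)c1=O)NO`: 5700000 nM
- Compound 2 `CC[C@H](Nc1c(NCCCCCC(=O)NO)c(=O)c1=O)c1ccccc1`: 57000000 nM

Going by the values given here, in a physicochemical assay for solubility, with a stated time of 24 h, tested at 30 mg/mL (on this read-out higher numbers stand for higher solubility and lower numbers for lower solubility), compound 1 gives 5700000 nM, the lower of the two numbers measured so far. Compound 3 `Cc1cccc(Nc2c(NCCCCCC(=O)NO)c(=O)c2=O)c1` has not yet been measured. It differs from compound 1 by 3-methylphenyl in place of benzyl on a nitrogen on an aromatic ring, with 3-methylphenyl in place of benzyl on a nitrogen on an aromatic ring.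

Among the compounds with values here, only one measured step is available: a 10-fold higher number from compound 1 to compound 2 (1.00 log units; beyond the scatter). Within the data shown here, that step puts ethyl in place of hydrogen on a saturated chain carbon, which is a different change from the one in compound 3. It therefore gives no direction here, though it does show that a modest step beyond the scatter can occur within this small set. With no firm direction, no step beyond the scatter is expected, and the expected change is a 1.1-fold lower number from compound 1 to compound 3 (0.06 log units; within the scatter). For compound 3 the estimated value is 5000000 nM, with an expected range from 1200000 nM to 25000000 nM.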

Compound 3, solubility: 11000000 nM
The estimate for compound 3 lay 2.2-fold (0.34 log units) below the measured number; low and high end bracket the measured number.
By their numbers in this assay, from the lowest: compounds 1 and 3 (each within the scatter of the next); then compound 2.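

In this assay, the change at this nitrogen gives a 1.9-fold higher number from compound 1 to compound 3 (0.29 log units; within the scatter) and so stays within the usual scatter of repeated measurements. The earlier step concerned a saturated chain carbon, whereas this one shows that, at a nitrogen on an aromatic ring, benzyl can give way to 3-methylphenyl, a group with the same count of heavy atoms, without a step that can be told from that scatter. Nothing available explains this result.

A single pair at this position cannot show whether other groups on the same nitrogen would also stay within the scatter. Plain phenyl, or a phenyl ring carrying an amine or a carboxylic acid in place of the methyl, could move the number in either direction, and the compounds shown do not settle this.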